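The source may report more compounds than this note shows. Statements on the series, on what has been measured and on what is new or still open speak of the compounds shown alone.

The measured compounds:
compound 1 `Cn1cnnc1SCC(=O)N/N=c1/scc(-c2ccc(C#N)cc2)n1-c1ccccc1`, which in a functional assay on C6 cells (Rattus norvegicus) for cytotoxicity, read by MTT assay, with a stated time of 24 h, tested at 6 ug/mL (on this read-out higher numbers stand for a weaker effect at the one concentration tested and lower numbers for a stronger effect), gives 70.2%;
compound 2 `Cn1cnnc1SCC(=O)N/N=c1/scc(-c2ccccc2)n1-c1ccccc1`, which in this assay gives 90%;
compound 3 `O=C(CSc1nnnn1-c1ccccc1)N/N=c1/scc(-c2ccccc2)n1-c1ccccc1`, which in this assay gives 52.1%.

Compound 2 and compound 1 differ in one place: cyano in place of hydrogen on an aromatic carbon. That change made the step of a number 19.8 percentage points lower from compound 2 to compound 1 (beyond the scatter). Compound 2 and compound 3 differ in the group carried on the sulfur: 1-phenyl-1H-tetrazol-5-yl in place of 4-methyl-4H-1,2,4-triazol-3-yl on a sulfur. That change made the step of a number 37.9 percentage points lower from compound 2 to compound 3 (beyond the scatter), and compound 3 holds the lowest of the three numbers, with each of the other two standing beyond the scatter above it.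

Compound 4 `N#Cc1ccc(-c2cs/c(=N/NC(=O)CSc3nnnn3-c3ccccc3)n2-c2ccccc2)cc1` has not yet been measured. It differs from compound 3 by cyano in place of hydrogen on an aromatic carbon. Within the data shown here, this is the same change, at the same place, as the one from compound 2 to compound 1, now made on the core of compound 3 instead of the core of compound 2; the two cores differ in the group on the sulfur, as described. The change has occurred only once among the measured compounds, so the expectation rests on a single earlier instance on a different core.

Resting on the earlier step of a number 19.8 percentage points lower from compound 2 to compound 1 (beyond the scatter) for the same change, compound 4 is expected to show a step of similar size, a number 17.1 percentage points lower from compound 3 to compound 4 (beyond the scatter). Compound 4 is therefore estimated in this assay at 35%, with a range from 20% to 55%.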

Compound 4, a percentage reported as activity, at one concentration (the size of the read-out at that concentration, not a potency): 78.8%
Compound 4: middle estimate off by 43.8 percentage points, on the low side; measured number above the stated range.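

In this assay, cyano in place of hydrogen on an aromatic carbon now gave a number 26.7 percentage points higher from compound 3 to compound 4 (beyond the scatter), which stands for a weaker effect, so the change that strengthened the effect on the core of compound 2 weakened it on the core of compound 3: the same change on two cores in this assay, a number 19.8 percentage points lower (beyond the scatter) from compound 2 to compound 1 and a number 26.7 percentage points higher (beyond the scatter) from compound 3 to compound 4, 46.5 percentage points apart, beyond the scatter of two such steps. Read the other way, the swap of the group on the sulfur gave a number 8.6 percentage points higher from compound 1 to compound 4 (within the scatter), so the strong gain it brought on the core without cyano does not appear on the core with cyano: the same change on two cores in this assay, a number 37.9 percentage points lower (beyond the scatter) from compound 2 to compound 3 and a number 8.6 percentage points higher (within the scatter) from compound 1 to compound 4, 46.5 percentage points apart, beyond the scatter of two such steps. This shows that in these four compounds neither change has an effect that can be carried over on its own, since the outcome of each depends on what the other place holds, but it does not show why, and one such set of four compounds gives no rule for the wider series.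

On these data alone, it remains open whether the same reversal would appear with another group on that aromatic carbon, such as fluoro, methoxy or an amine. As far as these compounds go, it is equally open whether it would appear with another group on the sulfur, such as a 1-methyl-1H-tetrazol-5-yl group or a longer alkyl chain.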